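Working notes: from compound 3 to compound 4

The source may hold more compounds than are shown below. What is called first, only, known or untested is meant among the compounds shown, and "the series" means these compounds.

Measured in a functional assay on A 172 cells (Homo sapiens) for cytotoxicity, read by colorimetric assay and MTT assay; on this read-out higher numbers stand for weaker inhibition and lower numbers for stronger inhibition:
- compound 1 `COc1cccc2cc(-c3ccccc3)c(O)nc12`: 10000 nM
- compound 2 `COc1cc(OC)c2cc(-c3ccc(OCc4ccccc4)cc3)c(O)nc2c1`: 10000 nM
- compound 3 `COc1ccc(-c2cc3c(OC)cc(OC)cc3n(CCCC#N)c2=O)cc1`: 10000 nM

Compound 3 at 10000 nM stands level with compound 1 and compound 2, and nothing separates the three beyond the scatter. The next compound to be tested, compound 4 `COc1ccc(-c2cc3c(OC)cc(OC)cc3n(CCC#N)c2=O)cc1`, differs from compound 3 in one place: cyano in place of cyanomethyl on a saturated chain carbon, two bonds along the chain from an aromatic nitrogen. This is cyano in place of cyanomethyl on a saturated chain carbon, two bonds along the chain from an aromatic nitrogen. Cut one bond further out, the same difference reads 3-cyanopropyl to 2-cyanoethyl.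

For the measured compounds named here, no two measured compounds differ in only one place, so the data hold no direct measure of a change of this kind. Going by the values given here, the only guide is the flat set of values. Compound 1 at 10000 nM and compound 2 at 10000 nM carry no such nitrile chain, yet they match compound 3 at the digits given. On that basis, no step beyond the scatter is expected in this assay, in either direction. The estimated change is no change at the digits printed from compound 3 to compound 4 (within the scatter). Compound 4 is expected at 10000 nM, with an estimated range from 5000 nM to 20000 nM.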

Compound 4, half-maximal inhibitory concentration: 10000 nM
Compound 4: middle estimate and measured number agree at the digits printed; the range from low to high includes it.
By their numbers in this assay, from the lowest: compounds 1, 2, 3 and 4 (each within the scatter of the next).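

In this assay the series now has its first comparison of compounds that differ in one place: the change of cyano in place of cyanomethyl on a saturated chain carbon, two bonds along the chain from an aromatic nitrogen, reads no change at the digits printed from compound 3 to compound 4 (within the scatter) and so gives a direct reading at this position. The earlier compounds shown here could only be set side by side, since they differ in more than one place, whereas this pair isolates the step from 3-cyanopropyl to 2-cyanoethyl and shows that this one change does not separate the two compounds on this read-out. No accompanying measurement bears on why the two compounds read alike.

Only two nitrile chains are compared at this position, so the pair does not show whether the chain length or the nitrile matters once a different group is present. On these data alone, a longer chain, a primary amine or a carboxylic acid at the chain end remains open, as does whether any such group would move a compound away from compound 4 at 10000 nM by more than the scatter.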